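Dichloro versus chloro-nitro aryl in two trimethoxyphenyl series

The source may report more compounds than this note shows. Statements on the series, on what has been measured and on what is new or still open speak of the compounds shown alone.

Two cores appear. Compound 3 `COc1cc(C2=NN(C(C)=O)C(c3ccc(Cl)c([N+](=O)[O-])c3)O2)cc(OC)c1OC` carries a 4-chloro-3-nitrophenyl group on one core; in a functional assay on BGC-823 cells (Homo sapiens) for antiproliferative activity, read by MTT assay, tested at 5 uM (a lower number here means a weaker effect, a higher number a stronger effect of the compound at the concentration tested), compound 3 gives 0%. Compound 1 `COc1cc(C2=NN(C(C)=O)C(c3ccc(Cl)c(Cl)c3)O2)cc(OC)c1OC` differs from it by chloro in place of nitro on an aromatic carbon, and in this assay compound 1 gives 3.1%, so that a number 3.1 percentage points higher from compound 3 to compound 1 (within the scatter). Compound 2 `COc1cc(C(=O)N/N=C/c2ccc(Cl)c([N+](=O)[O-])c2)cc(OC)c1OC` belongs to the second core; the difference between the two cores is not broken down here. In this assay compound 2 gives 2.3%, which sits within the scatter of both compound 1 and compound 3, so no order among the three is claimed.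

Compound 4 `COc1cc(C(=O)N/N=C/c2ccc(Cl)c(Cl)c2)cc(OC)c1OC` is the unmeasured member of the second core and differs from compound 2 by chloro in place of nitro on an aromatic carbon. The place of the change is the same as in the pair of compound 3 and compound 1, so it counts as the same change. Because a number 3.1 percentage points higher from compound 3 to compound 1 (within the scatter) stayed within the scatter, the step from compound 2 to compound 4 is expected to be small, about a number 2.7 percentage points higher from compound 2 to compound 4 (within the scatter). Compound 4 is therefore estimated at 5%, between 0% and 14%.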

Compound 4, a percentage reported as inhibition, at one concentration (the size of the read-out at that concentration, not a potency): 32.7%
Compound 4: the middle estimate sits 27.7 percentage points below what was measured, and the stated range ends below it.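

In this assay, chloro in place of nitro on an aromatic carbon gives a number 30.4 percentage points higher from compound 2 to compound 4 (beyond the scatter), so on the core of compound 2 this change is not the small step seen on the other core. The change therefore does not carry over in size from one core to the other: the same change on two cores in this assay, a number 3.1 percentage points higher (within the scatter) from compound 3 to compound 1 and a number 30.4 percentage points higher (beyond the scatter) from compound 2 to compound 4, 27.3 percentage points apart, beyond the scatter of two such steps
These two pairs show only that the result of this one change depends on the core that bears it; they do not show which part of the core is responsible, nor whether the difference would hold for any other replacement at that place.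

As far as these compounds go, it remains open whether an amine or a carboxylic acid in place of the nitro on the core of compound 2 would read like compound 4 or like compound 2. Also open, from the compounds shown here alone, is whether the large step comes from the chloro entering or the nitro leaving, and whether the two cores would part in the same way with either of those groups.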